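From 1H-indol-6-yl to furan-2-yl on the shared core

The source may report more compounds than this note shows. Statements on the series, on what has been measured and on what is new or still open speak of the compounds shown alone.

Among the compounds with values here, in a functional assay on A549 cells (Homo sapiens) for antiproliferative activity, read by MTT assay, with a stated time of 48 h (a lower number here means a stronger inhibitor, a higher number a weaker inhibitor), compound 1 (`COc1cc(-c2cccc3nc(-c4ccc(F)cc4)oc23)cc(OC)c1OC`) gives 8700 nM and compound 2 (`COc1cc(-c2cccc3nc(-c4ccc5cc[nH]c5c4)oc23)cc(OC)c1OC`) gives 55 nM as the lower of the two numbers so far. Compound 3 (`COc1cc(-c2cccc3nc(-c4ccco4)oc23)cc(OC)c1OC`) carries furan-2-yl in place of 1H-indol-6-yl on an aromatic carbon and keeps the rest of compound 2. Within the data shown here, one measured step bears on this change: a 160-fold lower number from compound 1 to compound 2 (2.20 log units; beyond the scatter) is large and beyond the scatter, with 1H-indol-6-yl in place of 4-fluorophenyl. Among the measured compounds shown here, compound 3 gives up that 1H-indol-6-yl and no measured compound carries furan-2-yl. For the measured compounds named here, with compound 1 at 8700 nM as the only measured compound lacking 1H-indol-6-yl, a large step to a higher number is expected in this assay with its size uncertain. The expected move is a 45-fold higher number from compound 2 to compound 3 (1.66 log units; beyond the scatter) on this reading. For compound 3 the estimate is 2500 nM (expected range 400 nM to 12000 nM).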

Compound 3, half-maximal inhibitory concentration: 10300 nM
The estimate for compound 3 lay 4.1-fold (0.61 log units) below the measured number; the measured number falls inside the stated range.
By their numbers in this assay, from the lowest: compound 2; then compounds 1 and 3 (each within the scatter of the next).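

Furan-2-yl does not retain the low number seen with 1H-indol-6-yl at this aromatic carbon: in this assay there is a 190-fold higher number from compound 2 to compound 3 (2.27 log units; beyond the scatter) in the same assay. The step of a 1.2-fold higher number from compound 1 to compound 3 (0.07 log units; within the scatter) places furan-2-yl and 4-fluorophenyl level at this position, so two different replacements of 1H-indol-6-yl now give numbers within the scatter of each other. Among these three compounds, only compound 2 stands apart, and the low number is tied to 1H-indol-6-yl rather than to any aromatic ring at this carbon.

Going by these compounds, whether that low number depends on the fused ring pair or the hydrogen-bond donor of 1H-indol-6-yl stays open, as does where a phenyl ring carrying an amine or a carboxylic acid would fall. No supporting measurement is available to explain the difference between these groups.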